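The source may hold more compounds than are shown below. What is called first, only, known or untested is meant among the compounds shown, and "the series" means these compounds.

Measured in an in vivo ADME assay on the whole organism (strain Mongrel) for metabolic stability, with Canis familiaris (Canis lupus familiaris) as the target; on this read-out lower numbers stand for a shorter-lived compound and higher numbers for a longer-lived compound: compound 1 `C[C@@H](NC(=O)C1(NC(=O)c2cncc(Cl)n2)CC1)c1ccc(-n2nc(Cl)c3ccccc32)cc1F` gives 15.1 h; compound 2 `C[C@@H](NC(=O)C1(NC(=O)c2cncc(Cl)c2)CC1)c1ccc(-n2nc(Cl)c3ccccc32)cc1F` gives 6 h.

For the measured compounds named here, compound 2 stands lowest of the two numbers; the only step seen is a 2.5-fold lower number from compound 1 to compound 2 (0.40 log units; beyond the scatter). Compound 3 `Cc1nnsc1C(=O)NC1(C(=O)N[C@H](C)c2ccc(-n3nc(Cl)c4ccccc43)cc2F)CC1` differs from compound 2 by 4-methyl-1,2,3-thiadiazol-5-yl in place of 5-chloropyridin-3-yl on a carbonyl carbon. Going by the values given here, no measured step exchanges a six-membered ring for a five-membered ring at that carbonyl, so only the step from compound 1 to compound 2 shows how much a change at this place can move this assay. For compound 3 the expected step is no change at the digits printed from compound 2 to compound 3 (within the scatter), not beyond the scatter in either direction. The estimate for compound 3 is 6 h, within 2.4 h to 15 h.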

Compound 3, half-life: 2.4 h
For compound 3 the middle estimate is 2.5-fold (0.40 log units) above the measured one, within the range that was stated.
By their numbers in this assay, from the lowest: compound 3; then compound 2; then compound 1.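

In this assay, a five-membered aromatic ring now stands on this carbonyl carbon, and 4-methyl-1,2,3-thiadiazol-5-yl in place of 5-chloropyridin-3-yl gives a 2.5-fold lower number from compound 2 to compound 3 (0.40 log units; beyond the scatter). For the compounds shown here, in place of 6-chloropyrazin-2-yl, the same group gives a 6.3-fold lower number from compound 1 to compound 3 (0.80 log units; beyond the scatter), so this place spans a wider range than the single earlier step showed. Nothing available gives a reason for this order.

Going by these compounds, it remains open whether the methyl group or the five-membered ring goes with the lower number. On these data alone, how a plain phenyl ring at this carbonyl would read in this assay is also open.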